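The source may hold more compounds than are shown below. What is called first, only, known or untested is meant among the compounds shown, and "the series" means these compounds.

Measured compounds in a functional assay on cells (Erythrocyte, Rattus norvegicus) for inhibition, read by hemolysis, with a stated time of 1 h; a lower number here means a stronger inhibitor, a higher number a weaker inhibitor:
compound 1 `COc1cc(OC)c(OC)cc1/C=C/C(=O)c1cc(Cc2ccccc2)cc(Cc2ccccc2)c1` — 2.17 ug/mL
compound 2 `COc1cc(OC)c(OC)cc1/C=C/C(=O)c1ccc(O)cc1O` — 2.37 ug/mL
compound 3 `COc1cc(OC)c(C2CC(=O)c3cc(O)ccc3O2)cc1OC` — 2.14 ug/mL

The three numbers sit close together. Compound 2 shows a number that differs from compound 1 and from compound 3 by gaps lying within the usual scatter, so no order among the three can be read from these values.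

Compound 4 `COc1cc(OC)c(OC)cc1/C=C/C(=O)c1ccc(Br)cc1` has not yet been measured. It differs from compound 2 in one place: 4-bromophenyl in place of 2,4-dihydroxyphenyl on a carbonyl carbon. Among the compounds with values here, no measured pair shows a change of this kind, so the size of the step is unknown; a modest weakening is expected, of the order of the step of a 1.5-fold higher number from compound 2 to compound 4 (0.17 log units; within the scatter), though a result within the scatter of compound 2 cannot be excluded. Compound 4 is therefore estimated at 3.5 ug/mL, with a likely range from 1.5 ug/mL to 9 ug/mL.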

Compound 4, half-maximal inhibitory concentration: 2.3 ug/mL
Beside the measured number, compound 4's estimate is 1.5-fold (0.18 log units) above it, and the stated range covers the measured number.
By their numbers in this assay, from the lowest: compounds 3, 1, 4 and 2 (each within the scatter of the next).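

In this assay, 4-bromophenyl in place of 2,4-dihydroxyphenyl on a carbonyl carbon gives a 1.0-fold lower number from compound 2 to compound 4 (0.01 log units; within the scatter). This first one-place comparison shows that, at this position, a group with no hydrogen-bond donors and one with hydrogen-bond donors give numbers that cannot be told apart. Nothing given explains this result.

The compounds shown leave open whether this tolerance extends to an amine or a carboxylic acid on the same ring. They also leave open how the bromine and the hydroxyl groups would each fare alone.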